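Trifluoromethyl for methyl in an inactive triazole series

The compounds below may be only part of what the source reports. "The series", "measured", "known", "first", "only" and "open" are said of these compounds alone.

Compound 1 `C=C1C[C@]23C[C@@]1(O)CC[C@@H]2c1cccc(C)c1[C@@H]3Cn1cc(-c2ccc(C)cc2)nn1` carries a 4-methylphenyl group on its triazole. In a functional assay on A549 cells (Homo sapiens) for cytotoxicity, read by MTT assay, with a stated time of 4 days (a lower number here means a stronger inhibitor, a higher number a weaker inhibitor), compound 1 gives > 20000 nM, which is a limit of the assay and not a number. Among the measured compounds shown here, compound 2 `C=C1C[C@]23C[C@@]1(O)CC[C@H]2c1ccc(OS(=O)(=O)c2ccc(C)cc2)c(C)c1[C@@H]3Cn1cc(-c2ccccc2)nn1` is the only other measured member of the series. In this assay compound 2 gives > 20000 nM, likewise a limit. For the measured compounds named here, compound 1 therefore stands at the limit of > 20000 nM in this assay, at which 2 of the 2 values shown sit, and no measured step leads away from it. Compound 3 `C=C1C[C@]23C[C@@]1(O)CC[C@@H]2c1cccc(C)c1[C@@H]3Cn1cc(-c2ccc(C(F)(F)F)cc2)nn1` differs from compound 1 in one place: trifluoromethyl in place of methyl on an aromatic carbon. Going by the values given here, no pair of measured compounds calibrates this change. Because both known values sit at the limit of > 20000 nM in this assay, at which 2 of the 2 values shown sit, the expected step is a step that the limit leaves unreadable from compound 1 to compound 3, meaning no movement resolvable beyond the scatter. Compound 3 is accordingly estimated at 30000 nM, within a range from 10000 nM to 100000 nM, most probably reported again only as a limit.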

Compound 3, half-maximal inhibitory concentration: > 20000 nM
Compound 3 gave a limit, no number; the forecaster's own chance of this, stated with the estimate: 75%; the middle value lies beyond the limit too.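

No step can be read from compound 1 to compound 3, since each compound gives only a limit of the assay and not a number: the limit of > 20000 nM in this assay, at which 3 of the 3 values shown sit. The compounds shown leave open whether any change to the shared core would bring a measurable value in this assay at all.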